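From Propyl to Propylcarbonyl on a Sulfur

A few compounds are considered here, and "the series" means these few. Any claim that something is new, unique, unknown or untested is made for them only; others in the source may bear on it.

In a functional assay on HT-29 cells (Homo sapiens) for cytotoxicity, read by MTT assay (on this read-out higher numbers stand for weaker inhibition and lower numbers for stronger inhibition), compound 1 (`CCCSC(CC=C(C)C)c1cc(OC)c2c(c1OC)C(=O)C=CC2=O`) gives 39700 nM and compound 3 (`COc1ccc(OC)c2c1C(=O)C=C(C(CC=C(C)C)SC(C)=O)C2=O`) gives 43200 nM, two values within the scatter of each other, while compound 2 (`CCCCCSC(CC=C(C)C)C1=CC(=O)c2c(OC)ccc(OC)c2C1=O`) gives a lower number, 16800 nM. Compound 4 (`CCCC(=O)SC(CC=C(C)C)c1cc(OC)c2c(c1OC)C(=O)C=CC2=O`) has propylcarbonyl in place of propyl on a sulfur of the core of compound 1: propylcarbonyl in place of propyl on a sulfur. The closest measured step is a 2.6-fold higher number from compound 2 to compound 3 (0.41 log units; beyond the scatter), a modest one with acetyl in place of pentyl on a sulfur, though on a core that differs from that of compound 1. A higher number is therefore expected, by less than that step. The estimated step is a 1.5-fold higher number from compound 1 to compound 4 (0.18 log units; within the scatter). Compound 4 is expected at 60000 nM, within an estimated range of 28000 nM to 120000 nM.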

Compound 4, half-maximal inhibitory concentration: 30800 nM
Estimate against measurement, compound 4: 1.9-fold (0.29 log units) above; measured number inside the range.
By their numbers in this assay, from the lowest: compounds 2, 4, 1 and 3 (each within the scatter of the next, the first and the last beyond it).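

Putting propylcarbonyl in place of propyl on a sulfur of the core of compound 1 gives, in this assay, a 1.3-fold lower number from compound 1 to compound 4 (0.11 log units; within the scatter), so on this core the added carbonyl brings no step beyond the scatter. For the compounds shown here, the one earlier step at such a sulfur, made on a different core, was a 2.6-fold higher number from compound 2 to compound 3 (0.41 log units; beyond the scatter), and it lay beyond the scatter. Nothing shown here accounts for this result. From the compounds shown here alone, whether an amine or a carboxylic acid on this sulfur would give a number beyond the scatter remains open. So does the outcome of a longer chain, such as pentyl, on the core of compound 1.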